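Removing the Methyl Group Before the Next Measurement

A few compounds are considered here, and "the series" means these few. Any claim that something is new, unique, unknown or untested is made for them only; others in the source may bear on it.

Of the compounds shown here, two have so far been measured in a functional assay on the whole organism for inhibition, with Rattus norvegicus as the target, at a dose of 3 mg/kg by the oral route; on this read-out lower numbers stand for a weaker effect and higher numbers for a stronger effect at the one dose given. Compound 1 `Cc1cccc(C(=O)Nc2nn[nH]n2)n1` gives 46% in this assay. Compound 2 `Cc1ccnc(C(=O)Nc2nn[nH]n2)c1` gives 42% in this assay. On the numbers shown, compound 2 holds the lower of the two values, but its nearest neighbour, compound 1, sits within the usual scatter of it, so the two values cannot be told apart and neither compound can be called the stronger.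

Compound 3 `O=C(Nc1nn[nH]n1)c1ccccn1` differs from compound 2 in one place: hydrogen in place of methyl on an aromatic carbon. Among the measured compounds shown here, no pair of measured compounds shows the effect of such a change, so the direction of the step has to be judged from the two values in hand. Since compound 1 with 46% and compound 2 with 42% lie so close together, the methyl in either place gives no sign of carrying the effect, and a step of no more than the scatter is expected. Compound 3 is expected to give about 42% in this assay, with a range from 25% to 60%. The estimated step of no change at the digits printed from compound 2 to compound 3 (within the scatter) is expected to stay within the scatter.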

Compound 3, a percentage reported as inhibition, in the whole organism at one dose (the size of the read-out at that dose, not a potency): 29%
Compound 3: the middle estimate sits 13 percentage points above what was measured; low and high end bracket the measured number.
By their numbers in this assay, from the lowest: compound 3; then compounds 2 and 1 (each within the scatter of the next).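

In this assay, hydrogen in place of methyl on the aromatic carbon opposite the ring nitrogen gives a number 13 percentage points lower from compound 2 to compound 3 (beyond the scatter), and the same exchange at the methyl's other place gives a number 17 percentage points lower from compound 1 to compound 3 (beyond the scatter). The two methyl compounds alone could not show whether a methyl contributes at all, but both steps lie beyond the scatter, so at either place the methyl goes with a stronger effect at the one dose given than hydrogen does. No measurement shown here gives a reason for this difference.

What the compounds leave open is whether the effect depends on methyl itself or would also hold with another group on the same aromatic carbon, such as ethyl, methoxy, an amine or a chlorine atom. With only one dose shown, it also remains open whether these steps would hold at other doses, and whether a methyl at both places on the shared core would add to the effect of one.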